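Methyl in place of hydrogen: working notes on cytotoxicity

The compounds below may be only part of what the source reports. "The series", "measured", "known", "first", "only" and "open" are said of these compounds alone.

Of the compounds shown here, three have been measured so far: compound 1 `Cc1c(O)c(=O)ccn1CCCCNc1ccnc2cc(Cl)ccc12`, compound 2 `Cc1c(O)c(=O)ccn1CCCCCCNc1ccnc2cc(Cl)ccc12` and compound 3 `CCc1c(O)c(=O)ccn1CCCCNc1ccnc2cc(Cl)ccc12`. A fourth, compound 4 `CCc1c(O)c(=O)ccn1CCCCCCNc1ccnc2cc(Cl)ccc12`, is still to be measured.

In an ADME assay on KB cells (Homo sapiens) for cytotoxicity, read by resazurin assay, with a stated time of 72 h (on this read-out lower numbers stand for stronger inhibition and higher numbers for weaker inhibition), compound 1 gives 185000 nM. In this assay compound 3 gives 76000 nM. In this assay compound 2 gives 4000 nM, the lowest of the three numbers; the difference between compound 2 and compound 1 is not broken down here.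

Compound 3 differs from compound 1 by methyl in place of hydrogen on a saturated chain carbon bound to an aromatic carbon. This change gave a 2.4-fold lower number from compound 1 to compound 3 (0.39 log units; beyond the scatter).

Compound 4 differs from compound 2 by methyl in place of hydrogen on a saturated chain carbon bound to an aromatic carbon. This is the same change as that from compound 1 to compound 3, made at the same place, on the core of compound 2 rather than that of compound 1. Among the compounds with values here, only one instance of the change is measured, so the transfer rests on a single step.

The expectation for compound 4 is a step of about a 2.2-fold lower number from compound 2 to compound 4 (0.35 log units; beyond the scatter) in this assay, because a 2.4-fold lower number from compound 1 to compound 3 (0.39 log units; beyond the scatter) was modest and beyond the scatter, and the same change is made here. Compound 4 is therefore estimated at 1800 nM in this assay, with a likely range from 700 nM to 5000 nM.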

Compound 4, half-maximal inhibitory concentration: 44000 nM
Beside the measured number, compound 4's estimate is 24-fold (1.39 log units) below it; measured number outside the range, above it.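

On the core of compound 2, methyl in place of hydrogen on a saturated chain carbon bound to an aromatic carbon gives an 11-fold higher number from compound 2 to compound 4 (1.04 log units; beyond the scatter) in this assay, a large step and opposite in direction to the modest one on the core of compound 1. The change therefore does not carry from one core to the other in this series, in size or in direction, and the earlier step gives no safe guide to the later one: the same change on two cores in this assay, a 2.4-fold lower number (0.39 log units; beyond the scatter) from compound 1 to compound 3 and an 11-fold higher number (1.04 log units; beyond the scatter) from compound 2 to compound 4, 27-fold (1.43 log units) apart, beyond the scatter of two such steps

These steps show only that the result of this change depends on the core within these two matched pairs; they do not show why the direction reverses, or which of the two steps would be the more usual one on a further core in the series.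

The compounds shown leave open whether a longer chain at the same place, such as propyl or butyl, would continue the step from compound 1 to compound 3 or the step from compound 2 to compound 4. They also leave open how an amine or a carboxylic acid at the end of that chain would read out on either core.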